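This account rests on a few compounds, and the source may have more. Where it says the series, first, only, none or still open, it means among the compounds named here.

Of the compounds shown here, three built on one shared core have been measured in an assay for inhibition of 6-phosphofructo-2-kinase/fructose-2,6-bisphosphatase 3 (Homo sapiens), read by ADP-Glo, with a stated time of 2 h; a lower number here means a stronger inhibitor, a higher number a weaker inhibitor. Compound 1 `CNC(=O)c1ccncc1Nc1cc(-c2ccc3ccn(C)c3c2)c2nccnc2c1` gives 83 nM. Compound 2 `CN(C)C(=O)c1ccncc1Nc1cc(-c2ccc3ccn(C)c3c2)c2nccnc2c1` gives 499 nM, and the change between them reads a 6.0-fold higher number from compound 1 to compound 2 (0.78 log units; beyond the scatter). Compound 3 `Cn1cc(NC(=O)c2ccncc2Nc2cc(-c3ccc4ccn(C)c4c3)c3nccnc3c2)cn1` gives 33 nM, the lowest of the three numbers; the steps leading to it read a 2.5-fold lower number from compound 1 to compound 3 (0.40 log units; beyond the scatter) and a 15-fold lower number from compound 2 to compound 3 (1.18 log units; beyond the scatter), both beyond the usual scatter.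

Compound 4 `Cn1cc(CNC(=O)c2ccncc2Nc2cc(-c3ccc4ccn(C)c4c3)c3nccnc3c2)cn1` has not yet been measured. It differs from compound 3 in one place: (1-methyl-1H-pyrazol-4-yl)methyl in place of 1-methyl-1H-pyrazol-4-yl on an amide-type nitrogen. Within the data shown here, none of the measured steps makes this exact change, so the nearest guidance comes from the other changes made on the same amide-type nitrogen, which moved the number by a 6.0-fold higher number from compound 1 to compound 2 (0.78 log units; beyond the scatter) and by a 2.5-fold lower number from compound 1 to compound 3 (0.40 log units; beyond the scatter). Those steps were modest. A modest step is therefore expected for compound 4, more likely upward than downward, amounting to a 2.0-fold higher number from compound 3 to compound 4 (0.29 log units; within the scatter). In this assay compound 4 is estimated at 65 nM, with a range from 25 nM to 170 nM.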

Compound 4, half-maximal inhibitory concentration: 159 nM
Beside the measured number, compound 4's estimate is 2.4-fold (0.39 log units) below it; measured number inside the range.
By their numbers in this assay, from the lowest: compound 3; then compounds 1 and 4 (each within the scatter of the next); then compound 2.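

In this assay, the ring alone does not settle the result at this position: the entering group keeps the same 1-methyl-1H-pyrazol-4-yl ring and adds one carbon, yet the step reads a 4.8-fold higher number from compound 3 to compound 4 (0.68 log units; beyond the scatter). The advantage that compound 3 holds over compound 1 does not carry over to compound 4, as the step reads a 1.9-fold higher number from compound 1 to compound 4 (0.28 log units; within the scatter), although replacing the dimethylamino group of compound 2 with ((1-methyl-1H-pyrazol-4-yl)methyl)amino still gives a 3.1-fold lower number from compound 2 to compound 4 (0.50 log units; beyond the scatter). Nothing available explains why one added carbon changes the number this much.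

The compounds shown leave open whether a longer chain, such as a two-carbon link to the same ring, would move the number further. They also leave open whether a phenyl ring in place of the pyrazole would behave the same way, either attached directly or through one carbon.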